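Replacing octyl with 2-chlorophenyl on the shared core

This account rests on a few compounds, and the source may have more. Where it says the series, first, only, none or still open, it means among the compounds named here.

For the measured compounds named here, compound 1 `CCCCCCCCNc1nc(SCc2ccc(C(F)(F)F)cc2)nc2ccccc12` is the anchor of this small set: in a functional assay on MDA-MB-231 cells (Homo sapiens) for cytotoxicity, read by MTT assay, with a stated time of 72 h (a lower number here means a stronger inhibitor, a higher number a weaker inhibitor), compound 1 gives 22300 nM, the only numeric result among the three measured members. Compound 2 `CCCCCCCCCCCCCCNc1nc(SCc2ccc(C(F)(F)F)cc2)nc2ccccc12` carries hexyl in place of hydrogen on a saturated chain carbon; compound 2 returns only a limit of the assay, > 50000 nM. Compound 3 `FC(F)(F)c1ccc(CSc2nc(Nc3ccccc3C(F)(F)F)c3ccccc3n2)cc1` bears 2-(trifluoromethyl)phenyl in place of octyl on a nitrogen on an aromatic ring; compound 3 likewise returns a limit, > 50000 nM. Both measured steps point the same way, an at least 2.2-fold higher number from compound 1 to compound 2 (0.35 log units; beyond the scatter) and an at least 2.2-fold higher number from compound 1 to compound 3 (0.35 log units; beyond the scatter), and the limit of > 50000 nM in this assay, at which 2 of the 3 values shown sit, caps how far either can be placed.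

Compound 4 `FC(F)(F)c1ccc(CSc2nc(Nc3ccccc3Cl)c3ccccc3n2)cc1` is the unmeasured member. Relative to compound 1 the change is 2-chlorophenyl in place of octyl on a nitrogen on an aromatic ring. The step that bears on it is the aryl-for-octyl exchange an at least 2.2-fold higher number from compound 1 to compound 3 (0.35 log units; beyond the scatter), where the aryl partner carries trifluoromethyl rather than chlorine. With that precedent the expected outcome is a step of the same direction and comparable size, a 2.7-fold higher number from compound 1 to compound 4 (0.43 log units; beyond the scatter), most likely ending again at the limit of the assay. Compound 4 is therefore estimated at 60000 nM, within 25000 nM to 150000 nM.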

Compound 4, half-maximal inhibitory concentration: > 50000 nM
Compound 4 was reported as a limit; the forecaster's own chance of this, stated with the estimate: 70%; the middle value does not contradict the limit.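

Working notes on the group on the nitrogen: in this assay, a second aryl group, 2-chlorophenyl in place of octyl, gives an at least 2.2-fold higher number from compound 1 to compound 4 (0.35 log units; beyond the scatter). Together with compound 3, this shows that the weaker result on leaving octyl for an aryl group is not confined to 2-(trifluoromethyl)phenyl; it holds for both aryl groups in the set, and no aryl compound shown goes against it. The size of this step stays capped, and the step from compound 3 to compound 4, chloro in place of trifluoromethyl on an aromatic carbon, cannot be read: the limit of > 50000 nM in this assay, at which 3 of the 4 values shown sit.

For the compounds shown here, compound 1 therefore remains the only compound with a numeric result, and how far compounds 2, 3 and 4 lie beyond the limit remains open, as does any order among them. Also open, from the compounds shown here alone, is whether any group on this nitrogen can give a lower number than compound 1, for example a shorter chain such as butyl, an unsubstituted phenyl, a benzyl group, or an octyl chain ending in an amine or a carboxylic acid.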